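Solubility of the fused oxazolone ureas, step to compound 4

This account rests on a few compounds, and the source may have more. Where it says the series, first, only, none or still open, it means among the compounds named here.

Measured so far:
compound 1 `CC(C)CNC(=O)n1c(=O)oc2c(C3CCN(C)CC3)cccc21` 230000 nM
compound 2 `CN1CCN(c2ccc3c(c2)oc(=O)n3C(=O)NCCCCc2ccccc2)CC1=O` < 1000 nM
compound 3 `O=C(NCCCCc1ccccc1)n1c2c(oc1=O)CCNC2` 82000 nM

In a physicochemical assay for solubility, read by HPLC, in phosphate buffer, measured as kinetic solubility, with a stated time of 1 h, at pH 7.4, tested at 250 uM (a lower number here means a less soluble compound, a higher number a more soluble compound), compound 2 sits at the bottom of the set. The figure for compound 2 in this assay is a limit of the assay, not a number; (the limit of < 1000 nM in this assay, at which 1 of the 3 values shown sits). For the measured compounds named here, compound 1 in this assay gives 230000 nM, and compound 3 gives 82000 nM; no step between measured compounds is shared by a single change, so these three values are only read side by side.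

Compound 4 `CN1CCC(c2ccc3c(c2)oc(=O)n3C(=O)NCCCCc2ccccc2)CC1` is not yet measured. It differs from compound 2 in one place: 1-methylpiperidin-4-yl in place of 4-methyl-3-oxopiperazin-1-yl on an aromatic carbon. Going by the values given here, no measured step matches this change. The expectation for the step from compound 2 to compound 4 in this assay is a rise well beyond the scatter, given that compound 1, which also carries 1-methylpiperidin-4-yl, reaches 230000 nM in this assay, while the chain on the urea nitrogen is the same in compound 4 as in compound 3, which gives 82000 nM.

Compound 4 is expected to give 50000 nM in this assay, with a range from 5000 nM to 200000 nM, which means an estimated step of an at least 50-fold higher number from compound 2 to compound 4 (1.69 log units; beyond the scatter).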

Compound 4, solubility: 120000 nM
Estimate against measurement, compound 4: 2.4-fold (0.38 log units) below; the range from low to high includes it.
By their numbers in this assay, from the lowest: compounds 3, 4 and 1 (each within the scatter of the next, the first and the last beyond it). At a limit, below all of these: compound 2.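

In this assay the series now holds its first step at a single place: replacing 4-methyl-3-oxopiperazin-1-yl with 1-methylpiperidin-4-yl on an aromatic carbon of the shared core, with the chain on the urea nitrogen unchanged, gives an at least 120-fold higher number from compound 2 to compound 4 (2.07 log units; beyond the scatter) for this one change. Compound 1, compound 2 and compound 3 could only be read side by side, whereas this pair places the whole step on the group at this aromatic carbon. The figure for compound 2 is a limit of the assay and not a number: the limit of < 1000 nM in this assay, at which 1 of the 4 values shown sits.

The change alters several things at once, taking away one ring hetero atom, one hydrogen-bond acceptor and the double bond outside aromatic rings, and the compounds shown do not tell these apart. As far as these compounds go, a 4-methylpiperazin-1-yl group on the same aromatic carbon would keep both ring nitrogens of the group in compound 2 without its carbonyl, and where such a compound would fall relative to compound 2 and compound 4 remains open.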